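Methoxy added to the acetyl of compound 2

The compounds below may be only part of what the source reports. "The series", "measured", "known", "first", "only" and "open" are said of these compounds alone.

Compound 2 `CC(=O)N1CCCc2ccc(NC(=O)c3ccc(-c4ccccc4)cc3)cc21` and compound 1 `CC(=O)NCCN1CCCc2ccc(NC(=O)c3ccc(-c4ccccc4)cc3)cc21` share one core and differ only in the group on the ring nitrogen. In a functional assay for antagonist activity at transient receptor potential cation channel subfamily V member 1 (Homo sapiens), read by FLIPR and calcium flux (a higher number here means a more potent compound, by a factor of ten per unit of this negative logarithm, a lower number a less potent compound), compound 2 gives 7.2, and compound 1 gives 6.9; the step of a number 0.30 log units higher from compound 1 to compound 2 (within the scatter) is the only one measured, and it lies within the scatter. Compound 3 `COCC(=O)N1CCCc2ccc(NC(=O)c3ccc(-c4ccccc4)cc3)cc21` keeps the acetyl of compound 2 and alters it by methoxy in place of hydrogen on a saturated chain carbon bound to a carbonyl carbon. Among the measured compounds shown here, the single measured step bears on it only loosely, since it also touched the group on that nitrogen and was small, so a change of similar modest size, or none beyond the scatter, is expected in this assay for compound 3. Compound 3 is therefore expected to give 7.1 in this assay, within a range from 6.6 to 7.6, an expected step of a number 0.10 log units lower from compound 2 to compound 3 (within the scatter).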

Compound 3, negative logarithm of the antagonist equilibrium constant: 7.2
Compound 3: the middle estimate sits 0.10 log units below what was measured, and the stated range covers the measured number.
By their numbers in this assay, from the lowest: compounds 1, 2 and 3 (each within the scatter of the next).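

In this assay, among the compounds shown here, methoxy in place of hydrogen on a saturated chain carbon bound to a carbonyl carbon gives no change at the digits printed from compound 2 to compound 3 (within the scatter) and so stays within the scatter, the first reading of a change made on the acetyl itself rather than an exchange of the whole group on the nitrogen. The exchange of 2-acetamidoethyl for (methoxymethyl)carbonyl gives a number 0.30 log units higher from compound 1 to compound 3 (within the scatter) and also stays within the scatter, so this read-out does not separate the three groups carried on that nitrogen. Nothing measured here offers an explanation for these results. 

Going by these compounds, whether an amine, a carboxylic acid or a longer ether chain on that same carbon would also stay within the scatter remains open. So does the outcome of replacing the carbonyl itself with a sulfonyl.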